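Swapping the end group on compound 2

This account rests on a few compounds, and the source may have more. Where it says the series, first, only, none or still open, it means among the compounds named here.

Values measured so far in a physicochemical assay for lipophilicity, read by HPLC; a lower number here means a more polar compound, a higher number a more lipophilic compound
- Compound 1 `Cc1cc(CCCCCOc2c(C)cc(-c3nnn(C)n3)cc2C)on1` gives 3.6
- Compound 2 `Cc1cc(CCCOc2c(C)cc(-c3nnn(C)n3)cc2C)on1` gives 3.2
- Compound 3 `CC(=O)c1ccc(CCCCCOc2c(Cl)cc(C3=NCCO3)cc2Cl)o1` gives 4.6

Compound 2 (3.2) holds the lowest of the three numbers, with compound 1 nearest to it and compound 3 furthest away, both beyond the scatter.

Compound 4 `CC(=O)c1ccc(CCCOc2c(C)cc(-c3nnn(C)n3)cc2C)o1` differs from compound 2 in one place, with 5-acetylfuran-2-yl in place of 3-methyl-1,2-oxazol-5-yl on a saturated chain carbon, three bonds along the chain from an oxygen on an aromatic ring. For the measured compounds named here, no measured pair makes this exact swap. Going by the values given here, the one measured step, a number 0.40 log units lower from compound 1 to compound 2 (beyond the scatter), is modest but beyond the scatter. It alters the chain rather than exchanging the end group, so it offers only a rough sense of how large a single change can be here.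

Compound 3 (4.6) carries the 5-acetylfuran-2-yl group and has the highest number, but it differs from compound 2 in other places too, so it supports only a slight lean upward. The expected change is small and upward, estimated as a number 0.20 log units higher from compound 2 to compound 4 (within the scatter), and may not clear the scatter. Compound 4 is expected at 3.4 in this assay, with an estimated range from 2.9 to 3.9 for the measurement.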

Compound 4, partition coefficient: 3.2
Compound 4: the middle estimate sits 0.20 log units above what was measured; measured number inside the range.
By their numbers in this assay, from the lowest: compounds 2 and 4 (each within the scatter of the next); then compound 1; then compound 3.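

In this assay the exchange of the end group on a saturated chain carbon, three bonds along the chain from an oxygen on an aromatic ring, reads no change at the digits printed from compound 2 to compound 4 (within the scatter) and so leaves 5-acetylfuran-2-yl and 3-methyl-1,2-oxazol-5-yl indistinguishable at this place, although the entering group has 8 heavy atoms against 6 and one hetero atom in its ring against 2. The step from the longer-chain compound reads a number 0.40 log units lower from compound 1 to compound 4 (beyond the scatter) and matches a number 0.40 log units lower from compound 1 to compound 2 (beyond the scatter) in size, so in these three compounds the end group on the shorter chain makes no visible difference to that step. No measured finding is available to explain this result.

For the compounds shown here, the two end groups are compared on only one chain and one core, so it remains open whether they would also match on the longer chain of compound 1 or on the core of compound 3. From the compounds shown here alone, it is also open how far the number would move with a group of another kind at this place, such as an amine or a carboxylic acid.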